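Opening the ring on the side chain of compound 1

This account rests on a few compounds, and the source may have more. Where it says the series, first, only, none or still open, it means among the compounds named here.

Compound 1, `CC(C)=CCc1cc(C(=O)Nc2cc3ccc(OCC4CCCN(C)C4)c(C)c3oc2=O)ccc1O`, is measured in a functional assay on MCF7 cells (Homo sapiens) for antiproliferative activity (on this read-out lower numbers stand for stronger inhibition and higher numbers for weaker inhibition), and gives 2640 nM. That is the highest of the three numbers at hand. Compound 2, `CC(C)=CCc1cc(C(=O)Nc2cc3ccc(OCC4CCN(C)C4)c(C)c3oc2=O)ccc1O`, gives 1550 nM, and compound 3, `CCNCCCOc1ccc2cc(NC(=O)c3ccc(O)c(CC=C(C)C)c3)c(=O)oc2c1C`, gives 980 nM. The step of a 1.7-fold lower number from compound 1 to compound 2 (0.23 log units; within the scatter) stays within the scatter, whereas the step of a 2.7-fold lower number from compound 1 to compound 3 (0.43 log units; beyond the scatter) reaches beyond it. Compound 4, `CC(C)=CCc1cc(C(=O)Nc2cc3ccc(OCCCNCCO)c(C)c3oc2=O)ccc1O`, has not yet been measured. It differs from compound 1 in one place: 2-((2-hydroxyethyl)amino)ethyl in place of 1-methylpiperidin-3-yl on a saturated chain carbon bound to an oxygen on an aromatic ring. Among the compounds with values here, the closest precedent is the step from compound 1 to compound 3, where 1-methylpiperidin-3-yl also gave way to 2-(ethylamino)ethyl; that step, a 2.7-fold lower number from compound 1 to compound 3 (0.43 log units; beyond the scatter), was modest. The step of a 1.6-fold lower number from compound 2 to compound 3 (0.20 log units; within the scatter) points the same way but within the scatter. For compound 4 a modest drop of similar size is therefore expected, a 2.4-fold lower number from compound 1 to compound 4 (0.38 log units; beyond the scatter). The estimated value for compound 4 in this assay is 1100 nM, within a range from 450 nM to 2700 nM.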

Compound 4, half-maximal inhibitory concentration: 1560 nM
For compound 4 the middle estimate is 1.4-fold (0.15 log units) below the measured one; low and high end bracket the measured number.
By their numbers in this assay, from the lowest: compounds 3, 2, 4 and 1 (each within the scatter of the next, the first and the last beyond it).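

In this assay the open chain carrying a hydroxy group leaves compound 4 within the scatter of every earlier compound: against the ring-bearing compound 1 (a 1.7-fold lower number from compound 1 to compound 4 (0.23 log units; within the scatter)), against the ring-bearing compound 2 (a 1.0-fold higher number from compound 2 to compound 4 (0.00 log units; within the scatter)) and against the open-chain compound 3 (a 1.6-fold higher number from compound 3 to compound 4 (0.20 log units; within the scatter)). Hydroxy in place of hydrogen on the saturated chain carbon therefore produces no readable difference at this position, and the step from compound 1 to compound 4 does not clear the scatter as the step to compound 3 did. No measurement here offers an explanation for these results.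

On these data alone, what remains open is whether a carboxylic acid in place of this hydroxy group would give a step beyond the scatter. The same holds for a longer chain between the amine and the hydroxy group.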